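This account rests on a few compounds, and the source may have more. Where it says the series, first, only, none or still open, it means among the compounds named here.

Of the compounds shown here, three of one series have been tested in a functional assay on HCT-116 cells (Homo sapiens) for antiproliferative activity, read by MTT assay, with a stated time of 72 h; a lower number here means a stronger inhibitor, a higher number a weaker inhibitor. Compound 1 `COc1ccc(/C=C2\S/C(=N\c3ccccc3)N(C)C2=O)cc1` stands at a limit: in this assay compound 1 gives > 100000 nM, which is a limit of the assay and not a measured number. This is what the evidence shows for it: the limit of > 100000 nM in this assay, at which 1 of the 3 values shown sits. Compound 2 `COc1ccc(/C=C2/CN(C)/C(=N/c3ccc(OC)cc3)S2)cc1`, built on a different core, gives 15900 nM in this assay. Compound 3 `FC(F)(F)c1cc(/N=C2/NC/C(=C/c3ccccc3)S2)cc(C(F)(F)F)c1`, on that same different core, gives 16100 nM in this assay; the values of compound 2 and compound 3 lie within the scatter of each other, so no order between them can be stated.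

Compound 4 `COc1ccc(/C=C2\S/C(=N\c3ccc(F)cc3)N(C)C2=O)cc1` has not yet been measured. It differs from compound 1 in one place, (fluoro in place of hydrogen on an aromatic carbon), with the core of compound 1 kept unchanged.

Among the compounds with values here, no step between measured compounds on the core of compound 1 is available, so the size of the effect of a fluoro in place of hydrogen here cannot be read from the data. A single small substituent of this kind is expected to leave the reading where compound 1 stands, so the step is expected to be a number no higher from compound 1 to compound 4 (the limit leaves the size open), none beyond the scatter. Compound 4 is therefore estimated to give 100000 nM in this assay, with a range from 30000 nM to 300000 nM.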

Compound 4, half-maximal inhibitory concentration: 13300 nM
For compound 4 the middle estimate is 7.5-fold (0.88 log units) above the measured one, outside the stated range (below it).
By their numbers in this assay, from the lowest: compounds 4, 2 and 3 (each within the scatter of the next). At a limit, above all of these: compound 1.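

In this assay, within the data shown here, going from phenyl to 4-fluorophenyl gives an at least 7.5-fold lower number from compound 1 to compound 4 (0.87 log units; beyond the scatter), the first step that can be read on the core of compound 1. It shows that this aromatic carbon, para to a large group, is a place where replacing a single hydrogen with a fluoro can move the reading beyond the scatter, even though the fluoro adds only one heavy atom. Compound 1 gives > 100000 nM, which is a limit of the assay and not a measured number, so the step has a known minimum but no known full size: the limit of > 100000 nM in this assay, at which 1 of the 4 values shown sits.

On these data alone, whether a chloro group, a methoxy group or an amine on this same carbon would also lower the number remains open, as does whether a fluoro on another carbon of this ring would do so. Why the fluoro has this effect also remains open, and no step can be read between compound 4 and either compound 2 or compound 3, which stand on a different core.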